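The compounds below may be only part of what the source reports. "The series", "measured", "known", "first", "only" and "open" are said of these compounds alone.

Three close relatives share one core, and each carries a different ring on the amide-type nitrogen at the far end. Compound 1 `Nc1nn(Cc2cn(CC(=O)Nc3ccccc3)nn2)c2nc(-c3ccccc3)cc(C(F)(F)F)c12` bears an unsubstituted phenyl there; in a functional assay on HL-60 cells (Homo sapiens) for cytotoxicity, read by MTT assay, with a stated time of 24 h (on this read-out lower numbers stand for stronger inhibition and higher numbers for weaker inhibition), compound 1 gives 96.3 ug/mL. Compound 2 `Nc1nn(Cc2cn(CC(=O)Nc3ccc(F)cc3)nn2)c2nc(-c3ccccc3)cc(C(F)(F)F)c12` carries a 4-fluorophenyl, and in this assay compound 2 gives 44.8 ug/mL. Compound 3 `Nc1nn(Cc2cn(CC(=O)Nc3cccc(F)c3)nn2)c2nc(-c3ccccc3)cc(C(F)(F)F)c12` carries a 3-fluorophenyl, and in this assay compound 3 gives 63.9 ug/mL. Compound 3 lies between its two neighbours, but only by gaps that repeated testing could erase: a 1.5-fold lower number from compound 1 to compound 3 (0.18 log units; within the scatter), and a 1.4-fold higher number from compound 2 to compound 3 (0.15 log units; within the scatter). Within the data shown here, the one step that clears the scatter is a 2.1-fold lower number from compound 1 to compound 2 (0.33 log units; beyond the scatter), and even that is modest.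

Compound 4 `Nc1nn(Cc2cn(CC(=O)Nc3ccc(F)cc3Br)nn2)c2nc(-c3ccccc3)cc(C(F)(F)F)c12` changes the same ring: 2-bromo-4-fluorophenyl in place of 3-fluorophenyl on an amide-type nitrogen. Among the measured compounds shown here, the steps that bear on it are the three fluoro swaps above, none larger than modest, so adding a bromine alongside the fluorine on this ring is expected to move the number little in this assay, most likely toward the lower side seen with compound 2, but without confidence that it will clear the scatter. The estimate for compound 4 is therefore 45 ug/mL, within a range of 20 ug/mL to 110 ug/mL, which means an expected step of a 1.4-fold lower number from compound 3 to compound 4 (0.15 log units; within the scatter).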

Compound 4, half-maximal inhibitory concentration: 63.7 ug/mL
Estimate against measurement, compound 4: 1.4-fold (0.15 log units) below; low and high end bracket the measured number.
By their numbers in this assay, from the lowest: compounds 2, 4, 3 and 1 (each within the scatter of the next, the first and the last beyond it).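

Adding bromo to the 4-fluorophenyl ring of compound 2 gives a 1.4-fold higher number from compound 2 to compound 4 (0.15 log units; within the scatter) in this assay and so shows that this ring on the amide-type nitrogen can carry a bromine as well as a fluorine with no change that can be told from the scatter. The other two comparisons agree: 2-bromo-4-fluorophenyl in place of 3-fluorophenyl gives a 1.0-fold lower number from compound 3 to compound 4 (0.00 log units; within the scatter) and in place of unsubstituted phenyl gives a 1.5-fold lower number from compound 1 to compound 4 (0.18 log units; within the scatter) so compound 4 cannot be separated from any of the three earlier compounds, even though compound 1 and compound 2 do stand apart from each other. Nothing measured here offers a cause for this result.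

The compounds shown leave open whether bromo without the fluorine would behave the same way on this ring, and whether an amine or a carboxylic acid on the ring would produce a step beyond the scatter. They also leave open what a longer alkyl chain in place of the aromatic ring on the amide-type nitrogen would do to the number.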